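A benzyl group replaces 3-methoxyphenyl on the amide

This account rests on a few compounds, and the source may have more. Where it says the series, first, only, none or still open, it means among the compounds named here.

This short series shares one core and varies only the group on an amide-type nitrogen. Compound 1 (`CCCCc1oc2ccccc2c1C(=O)c1ccc(OCC(=O)NC(C)C)cc1`) carries isopropyl there and reads > 50000 nM in a functional assay on MCF7 cells (Homo sapiens) for antiproliferative activity, read by MTT assay, with a stated time of 24 h (a higher number here means a weaker inhibitor, a lower number a stronger inhibitor), which is a limit of the assay and not a number. Among the measured compounds shown here, compound 2 (`CCCCc1oc2ccccc2c1C(=O)c1ccc(OCC(=O)Nc2cccc(OC)c2)cc1`) carries 3-methoxyphenyl and gives 38500 nM in this assay, the only true number so far.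

Compound 3 (`CCCCc1oc2ccccc2c1C(=O)c1ccc(OCC(=O)NCc2ccccc2)cc1`) puts benzyl in place of 3-methoxyphenyl on that same nitrogen: benzyl in place of 3-methoxyphenyl on an amide-type nitrogen. For the measured compounds named here, one measured step bears on this change, and it is an at least 1.2-fold lower number from compound 1 to compound 2 (0.11 log units; that floor lies within the scatter). That single step is thin evidence, but it gives no sign that changing the group on this nitrogen clearly moves the number, so no step beyond the scatter is expected in this assay. The expected result is a 1.0-fold higher number from compound 2 to compound 3 (0.02 log units; within the scatter) and no direction can be favoured. With the limit of > 50000 nM in this assay, at which 1 of the 2 values shown sits, in mind, the measurement may also return only a limit. Compound 3 is estimated at 40000 nM, with an expected range from 20000 nM to 60000 nM.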

Compound 3, half-maximal inhibitory concentration: 19600 nM
Beside the measured number, compound 3's estimate is 2.0-fold (0.31 log units) above it, and the stated range ends above it.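

In this assay, among the compounds shown here, benzyl in place of isopropyl gives an at least 2.5-fold lower number from compound 1 to compound 3 (0.40 log units; beyond the scatter), which is the first step to clear the usual scatter, so the group on this amide-type nitrogen can move the number. Benzyl in place of 3-methoxyphenyl gives a 2.0-fold lower number from compound 2 to compound 3 (0.29 log units; within the scatter), so these two groups, each with a six-membered aromatic ring of carbon only, cannot be ranked against each other, and the methoxy oxygen that leaves with 3-methoxyphenyl brings no change that can be told from the scatter. The step from isopropyl to benzyl can be read only as a floor, because compound 1 stands at a limit of the assay and not at a true number: the limit of > 50000 nM in this assay, at which 1 of the 3 values shown sits.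

For the compounds shown here, with only three groups on this nitrogen, it remains open whether the gain over isopropyl goes with the aromatic ring or would also appear with a longer chain such as n-hexyl, or with a cyclohexylmethyl group. As far as these compounds go, how plain phenyl, 2-phenylethyl, or a group bearing an amine or a carboxylic acid would read in this assay also remains open, as does whether any change here could bring the number far below those of compound 2 and compound 3.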